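Swapping the Charged Terminus of a Long Alkoxy Chain

The source may hold more compounds than are shown below. What is called first, only, known or untested is meant among the compounds shown, and "the series" means these compounds.

Compound 1: `Cc1ccc(-n2cc(C(=O)Nc3cc(F)cc(F)c3)c(=O)c3ccc(N(C)C)nc32)cc1OCCCCCCC[N+]12CCN(CC1)CC2`; 5.07%
Compound 2: `Cc1ccc(-n2cc(C(=O)Nc3cc(F)cc(F)c3)c(=O)c3ccc(N(C)C)nc32)cc1OCCCCCCC[N+]1(C)CCCCC1`; 23.4%

In an assay on LX2 cells for inhibition of COL1A1 promoter (Homo sapiens), read by a luciferase reporter, with a stated time of 24 h, tested at 20 uM (a higher number here means a stronger effect of the compound at the concentration tested, a lower number a weaker effect), compound 1 gives 5.07% and compound 2 gives 23.4%. Compound 2 stands highest of the two measured numbers; its nearest neighbour is compound 1, and the step of a number 18.3 percentage points higher from compound 1 to compound 2 (beyond the scatter) lies beyond the scatter. Compound 3, `Cc1ccc(-n2cc(C(=O)Nc3cc(F)cc(F)c3)c(=O)c3ccc(N(C)C)nc32)cc1OCCCCCCC[n+]1ccccc1`, is not yet measured. It differs from compound 2 by a group of 6 heavy atoms (5 carbon, 1 nitrogen; one six-membered aromatic ring with 1 hetero atom) in place of a group of 7 heavy atoms (6 carbon, 1 nitrogen; one six-membered non-aromatic ring with 1 hetero atom), on a saturated chain carbon, seven bonds along the chain from an oxygen on an aromatic ring. Among the measured compounds shown here, the only measured step, from compound 1 to compound 2, also changes the charged group at the end of the chain, and it was modest. For the measured compounds named here, no step tells how a six-membered aromatic ring with one hetero atom compares with a six-membered non-aromatic ring at this place, so the direction is open. Compound 3 is therefore expected near compound 2, with a step of a number 3.4 percentage points lower from compound 2 to compound 3 (within the scatter) in this assay, the estimate being 20% in a range from 5% to 40%.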

Compound 3, a percentage reported as inhibition, at one concentration (the size of the read-out at that concentration, not a potency): 39.7%
For compound 3 the middle estimate is 19.7 percentage points below the measured one; the measured number falls inside the stated range.
By their numbers in this assay, from the lowest: compound 1; then compound 2; then compound 3.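

In this assay, putting the six-membered aromatic ring with 1 hetero atom in place of the six-membered non-aromatic ring on the saturated chain carbon gives a number 16.3 percentage points higher from compound 2 to compound 3 (beyond the scatter) and so shows that this position still responds when the terminal ring changes, while the wider comparison gives a number 34.6 percentage points higher from compound 1 to compound 3 (beyond the scatter) across the two terminal groups. The group that leaves and the group that enters both carry net charge +1 and neither has hydrogen-bond donors or acceptors, so these counts do not separate compound 2 from compound 3. Nothing at hand accounts for the rise.

As far as these compounds go, the aromatic terminus is represented by compound 3 alone, so it remains open whether an imidazolium group or a methyl-substituted pyridinium ring would read the same way. Also open, from the compounds shown here alone, is how a shorter alkoxy chain carrying the same terminal ring would behave.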